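The compounds below may be only part of what the source reports. "The series", "measured", "known", "first", "only" and "open" are said of these compounds alone.

Going by the values given here, compound 2 `Cc1c(Cl)cccc1Oc1ccc(N2C[C@@H](C(F)(F)F)C[C@H]2CC(=O)O)cc1` gives 430 nM in a functional assay on cells for agonist activity at Free fatty acid receptor 1 (Mus musculus), read by FLIPR and calcium flux, with a stated time of 100 s (on this read-out lower numbers stand for an effect already at smaller amounts and higher numbers for an effect only at larger amounts of compound), the lowest of the two numbers so far; compound 1 `Cc1cccc(Oc2ccc(N3C[C@@H](C(F)(F)F)C[C@H]3CC(=O)O)cc2)c1C` gives 500 nM, and a 1.2-fold lower number from compound 1 to compound 2 (0.07 log units; within the scatter) lies within the scatter. The step to compound 3 `COc1ccc(F)c(Cc2cccc(Oc3ccc(N4C[C@@H](C(F)(F)F)C[C@H]4CC(=O)O)cc3)c2C)c1` is 2-fluoro-5-methoxybenzyl in place of chloro on an aromatic carbon. Among the compounds with values here, the only measured comparison, exchanging chloro for methyl, was small and does not test the addition of a large group, so the expectation is loose. Compound 3 is estimated at 300 nM, with a range from 80 nM to 1500 nM, meaning an expected step of a 1.4-fold lower number from compound 2 to compound 3 (0.16 log units; within the scatter) in this assay.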

Compound 3, half-maximal effective concentration: 780 nM
Beside the measured number, compound 3's estimate is 2.6-fold (0.41 log units) below it, and the stated range covers the measured number.
By their numbers in this assay, from the lowest: compounds 2, 1 and 3 (each within the scatter of the next).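

In this assay, going by these compounds alone, the earlier compounds compared only small groups at this position, ortho to a methyl group, whereas 2-fluoro-5-methoxybenzyl, with 10 heavy atoms and its own aromatic ring, gives a 1.8-fold higher number from compound 2 to compound 3 (0.26 log units; within the scatter) and a 1.6-fold higher number from compound 1 to compound 3 (0.19 log units; within the scatter). Both steps lie within the scatter, so even this much larger group cannot be told apart from the small ones on this read-out. No evidence is available to explain this result. On these data alone, whether an amine on the added ring, or a longer chain in place of the benzyl group, would move the number beyond the scatter remains open.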